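Replacing the Benzyl Ester with a sec-Butyl Chain

The source may hold more compounds than are shown below. What is called first, only, known or untested is meant among the compounds shown, and "the series" means these compounds.

Compound 1 `CC1=C(C(=O)OCC(C)C)C(c2ccoc2)NC(=O)N1` gives 326 nM in an assay on membranes from HEK293 cells for displacement of a labelled ligand from adenosine receptor A2b (Homo sapiens), read by scintillation counting, with a stated time of 30 min; on this read-out lower numbers stand for stronger inhibition and higher numbers for weaker inhibition.
Compound 2 `CC1=C(C(=O)OCc2ccccc2)C(c2ccoc2)NC(=O)N1` gives 6650 nM in this assay.
Compound 3 `CC1=C(C(=O)OCc2ccccc2)C(c2cccs2)NC(=O)N1` gives 1920 nM in this assay.

Among these three, compound 2 has the highest number, that is, the weakest binding: compound 3 sits a 3.5-fold lower number from compound 2 to compound 3 (0.54 log units; beyond the scatter) away, and compound 1 further still. The unmeasured compound 4 `CCC(C)OC(=O)C1=C(C)NC(=O)NC1c1ccoc1` differs from compound 2 in one place: sec-butyl in place of benzyl on an oxygen next to a carbonyl group. Among the measured compounds shown here, the measured step that bears most directly on this is the one between compound 1 and compound 2, where the change ran the opposite way, with an alkyl chain giving way to benzyl, and the number rose by a 20-fold higher number from compound 1 to compound 2 (1.31 log units; beyond the scatter). Compound 4 reverses that kind of change, though sec-butyl is not the same chain as the isobutyl of compound 1. The step from compound 2 to compound 3 alters a different place and so does not speak to it. A large drop is therefore expected, a 17-fold lower number from compound 2 to compound 4 (1.22 log units; beyond the scatter), in this assay. For compound 4 the estimate in this assay is 400 nM, expected to lie between 130 nM and 1500 nM.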

Compound 4, inhibition constant: 201 nM
For compound 4 the middle estimate is 2.0-fold (0.30 log units) above the measured one; the measured number falls inside the stated range.
By their numbers in this assay, from the lowest: compounds 4 and 1 (each within the scatter of the next); then compound 3; then compound 2.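

On an oxygen next to a carbonyl group, sec-butyl in place of benzyl gives a 33-fold lower number from compound 2 to compound 4 (1.52 log units; beyond the scatter) in this assay, so the low number of compound 1 is not unique to isobutyl and a second alkyl chain reaches the same range. Sec-butyl in place of isobutyl gives a 1.6-fold lower number from compound 1 to compound 4 (0.21 log units; within the scatter), a step within the scatter, so these two chains cannot be told apart at this position. Nothing measured here explains why both chains give so much lower a number than benzyl.

As far as these compounds go, it remains open whether a shorter chain such as ethyl, a longer chain such as hexyl, or a saturated ring such as cyclohexyl would keep the number this low. Also open, from the compounds shown here alone, is whether sec-butyl in place of benzyl would lower the number as far in compound 3, which carries thiophen-2-yl instead of furan-3-yl.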